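Swapping an Ether Linker for an Alkene

The source may hold more compounds than are shown below. What is called first, only, known or untested is meant among the compounds shown, and "the series" means these compounds.

A small set of compounds shares one core, carrying a fused bicyclic aromatic group and a side chain that varies. Compound 1 `CNC(=O)COc1ccncc1-c1ccc2ccccc2c1` carries a (methylcarbamoyl)methoxy side chain, and in an assay on a protein complex for inhibition of CDK8/Cyclin C (Homo sapiens), with a stated time of 1 h (a higher number here means a weaker inhibitor, a lower number a stronger inhibitor), compound 1 gives "not determined" (no result reported). Compound 2 `O=C(COc1ccncc1-c1ccc2ccccc2c1)N1CCOCC1` has a related side chain ending in a morpholine amide, and in this assay compound 2 gives "not determined" (no result reported). Compound 3 `O=C(CCc1ccncc1-c1ccc2ccccc2c1)N1CCOCC1` differs from compound 2 in that its side chain is joined through two carbon atoms rather than through an oxygen atom; in this assay compound 3 gives 45.5 nM. Compound 4 `CN(C)C(=O)/C=C/c1ccncc1-c1ccc2ccccc2c1` is not yet measured. It differs from compound 1 in one place: 2-(dimethylcarbamoyl)ethenyl in place of (methylcarbamoyl)methoxy on an aromatic carbon. With no number for compound 1, no step size can be computed. Since compound 3 gives 45.5 nM with a carbon-linked side chain, compound 4 is expected to come out in a similar region, at 60 nM, with a likely range from 12 nM to 300 nM.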

Compound 4, half-maximal inhibitory concentration: 30.1 nM
The estimate for compound 4 lay 2.0-fold (0.30 log units) above the measured number; the range from low to high includes it.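

In this assay, among the compounds shown here, compound 1 has no single number, so no step from compound 1 to compound 4 can be read. The compounds shown leave open how much swapping (methylcarbamoyl)methoxy for 2-(dimethylcarbamoyl)ethenyl itself shifts inhibition. No evidence here bears on the value of compound 4.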